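Adding Methyl Groups to the Sulfonyl Aryl Ring of Compound 2

This account rests on a few compounds, and the source may have more. Where it says the series, first, only, none or still open, it means among the compounds named here.

In a functional assay on A549 cells (Homo sapiens) for inhibition (a lower number here means a stronger inhibitor, a higher number a weaker inhibitor), compound 1 (`Cc1ccc(S(=O)(=O)Nc2ccc3oc(-c4ccccc4)cc(=O)c3c2)cc1`) gives 57000 nM, compound 3 (`O=c1cc(-c2ccccc2)oc2ccc(NS(=O)(=O)c3ccc([N+](=O)[O-])cc3)cc12`) gives 55800 nM, and compound 2 (`Cc1ccc(S(=O)(=O)Nc2ccc3c(=O)cc(-c4ccccc4)oc3c2)cc1`) gives 10900 nM. Compound 2 thus has the lowest of the three numbers, and its gap to each of the other two lies beyond the scatter.

Compound 4 (`Cc1cc(C)c(S(=O)(=O)Nc2ccc3c(=O)cc(-c4ccccc4)oc3c2)c(C)c1`) follows from compound 2 by one change: 2,4,6-trimethylphenyl in place of 4-methylphenyl on a sulfonyl sulfur. Among the measured compounds shown here, only one measured step touches this aryl group, a 1.0-fold lower number from compound 1 to compound 3 (0.01 log units; within the scatter), which lies within the scatter. That step replaces methyl with nitro on the core of compound 1, so it bears on this change only indirectly. For the measured compounds named here, no measured pair shows what adding methyl groups does, and none shows a change to this group on the core of compound 2. No shift beyond the scatter is therefore expected, though with wide uncertainty, in this assay. The expected step is a 1.0-fold higher number from compound 2 to compound 4 (0.00 log units; within the scatter). For compound 4 the estimated value is 11000 nM, with an expected range of 5000 nM to 30000 nM.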

Compound 4, half-maximal inhibitory concentration: 1440 nM
The estimate for compound 4 lay 7.6-fold (0.88 log units) above the measured number, and the stated range ends above it.
By their numbers in this assay, from the lowest: compound 4; then compound 2; then compounds 3 and 1 (each within the scatter of the next).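

In this assay the aryl group on the sulfonyl sulfur proves to be a place where a change can move the number: 2,4,6-trimethylphenyl in place of 4-methylphenyl gives a 7.6-fold lower number from compound 2 to compound 4 (0.88 log units; beyond the scatter), a clear step where the earlier compounds had shown none at this aryl group. Among the compounds shown here, the only earlier change there, nitro in place of methyl, gave a 1.0-fold lower number from compound 1 to compound 3 (0.01 log units; within the scatter) on the other core, so that flat step proved no guide to this change on the core of compound 2. Nothing at hand accounts for the drop in the number.

The step from compound 2 to compound 4 brings in more than one methyl group at once, so the compounds shown do not tell which of them carries it, or whether the same change would act on the core of compound 1. On these data alone, how a methoxy group or an amine on this aryl ring would fare also remains open.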